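Trading the methylated sulfonamide for a methoxyphenyl sulfonamide

This account rests on a few compounds, and the source may have more. Where it says the series, first, only, none or still open, it means among the compounds named here.

Of the compounds shown here, three have so far been tested in a functional assay on HEK293 cells for agonist activity at probable G-protein coupled receptor 27 (Homo sapiens), read by a luciferase reporter and beta-arrestin recruitment, with a stated time of 10 min; a higher number here means that more compound is needed for the effect, a lower number that less compound is needed. Compound 1 `O=C(Nc1ccc(S(=O)(=O)Nc2ccccc2)cc1)c1cc(F)c(Cl)cc1F` gives 141 nM. For compound 2 `O=C(Nc1cccc(S(=O)(=O)Nc2ccccc2)c1)c1ccc(Cl)cc1Cl` the assay reports only a limit, > 100000 nM. Compound 3 `CN(c1ccccc1)S(=O)(=O)c1ccc(NC(=O)c2ccc(Cl)cc2Cl)cc1` gives 2570 nM, the higher of the two numbers; its nearest neighbour is compound 1, which sits well beyond the usual scatter below it.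

Compound 4 `COc1ccc(NS(=O)(=O)c2ccc(NC(=O)c3ccc(Cl)cc3Cl)cc2)cc1` differs from compound 3 in one place: (4-methoxyphenyl)amino in place of methyl(phenyl)amino on a sulfonyl sulfur. Compound 4 thus carries a sulfonamide bearing a hydrogen on its nitrogen, as compound 1 does, while keeping the amide portion of compound 3 unchanged. In this assay compound 4 is expected to give a lower number than compound 3, a step of a 6.4-fold lower number from compound 3 to compound 4 (0.81 log units; beyond the scatter). The estimate for compound 4 is 400 nM, with a likely range from 80 nM to 3000 nM.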

Compound 4, half-maximal effective concentration: > 100000 nM
Compound 4 was reported as a limit (the forecaster's own chance of this, stated with the estimate: 10%); middle value at least 250-fold (2.39 log units) away from the limit.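

The swap at this sulfonyl sulfur has a large effect, in the unfavourable direction: an at least 38-fold higher number from compound 3 to compound 4 (1.59 log units; beyond the scatter). A hydrogen on the sulfonamide nitrogen, arriving together with a methoxy on the ring, therefore brought no lower number here. The value of compound 4 is a limit, not a number: the limit of > 100000 nM in this assay, at which 2 of the 4 values shown sit.

The change removes the methyl and adds the methoxy at once, so the compounds shown cannot say which of the two drives the step. On these data alone, whether a fluorine or a hydroxyl in place of the methoxy would return a measurable number also stays open.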